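A few compounds are considered here, and "the series" means these few. Any claim that something is new, unique, unknown or untested is made for them only; others in the source may bear on it.

Of the compounds shown here, two on a shared core have been measured so far. In a functional assay on HT cells (Homo sapiens) for antiproliferative activity, read by fluorescence, with a stated time of 72 h (on this read-out lower numbers stand for stronger inhibition of growth and higher numbers for weaker inhibition of growth), compound 1 (`CC(C)c1n[nH]c2c(NCc3ccc(-c4ccccn4)cc3)nc(SCC(O)CN3CCNCC3)nc12`) gives 332 nM, and compound 2 (`CC(C)c1n[nH]c2c(NCc3ccc(-c4ccccn4)cc3)nc(SCC(C)(C)O)nc12`) gives 507 nM. Among the compounds with values here, compound 2 therefore stands within the scatter of compound 1, the only other compound with a number.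

Compound 3 (`CC(C)c1n[nH]c2c(NCc3ccc(-c4ccccn4)cc3)nc(SC(C)C(C)O)nc12`) keeps the core of compound 2 and alters only the group on a sulfur: 2-hydroxy-1-methylpropyl in place of 2-hydroxy-2-methylpropyl on a sulfur. The two have the same atoms, joined differently, with 2-hydroxy-1-methylpropyl in place of 2-hydroxy-2-methylpropyl.

Within the data shown here, only one measured step bears on this change, and only indirectly: a 1.5-fold higher number from compound 1 to compound 2 (0.18 log units; within the scatter). That step also alters the chain on the sulfur, replacing 1-hydroxy-2-(piperazin-1-yl)ethyl with 1-hydroxy-1-methylethyl. Among the measured compounds shown here, no measured pair tests a rearrangement of the same atoms, so the data favour no direction. No step beyond the scatter is therefore expected in this assay. The estimated step is a 1.0-fold lower number from compound 2 to compound 3 (0.01 log units; within the scatter). The estimated value for compound 3 is 500 nM, with an expected range of 220 nM to 1100 nM.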

Compound 3, concentration for 50% growth inhibition: 190 nM
Compound 3: middle estimate off by 2.6-fold (0.42 log units), on the high side; measured number outside the range, below it.
By their numbers in this assay, from the lowest: compounds 3, 1 and 2 (each within the scatter of the next, the first and the last beyond it).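

In this assay, within the data shown here, the swap of 2-hydroxy-2-methylpropyl for 2-hydroxy-1-methylpropyl on a sulfur comes with a 2.7-fold lower number from compound 2 to compound 3 (0.43 log units; beyond the scatter), the first step in this small set to lie beyond the scatter, so this position responds to how the same atoms are joined, even with the hydrogen-bond donor and acceptor counts unchanged. Against the 2-hydroxy-3-(piperazin-1-yl)propyl group of compound 1, the same 2-hydroxy-1-methylpropyl group gives a 1.7-fold lower number from compound 1 to compound 3 (0.24 log units; within the scatter), which stays within the scatter, so a chain with no ring matches the piperazine-bearing chain in this read-out. Nothing available accounts for the difference between the two isomeric chains.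

Every chain shown carries a hydroxyl, so the compounds leave open what happens when that hydroxyl gives way to a plain alkyl chain, an amine or a carboxylic acid. They also leave open whether the gain from 2-hydroxy-1-methylpropyl would hold for a longer chain of the same pattern, or with piperazine attached to it.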